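The compounds below may be only part of what the source reports. "The series", "measured", "known", "first", "only" and "open" are said of these compounds alone.

Measured compounds:
- Compound 1 `CCOC(=O)C1=C(C)N/C(=C/c2cc(C)n(-c3cccc(C(F)(F)F)c3)c2C)C1=O` gives 97 mL.min-1.g-1
- Compound 2 `CCOC(=O)C1=C(C)N/C(=C/c2cc(C)n(-c3cccc(OC)c3)c2C)C1=O` gives 150 mL.min-1.g-1

Both numbers come from an ADME assay on microsomes from liver (Mus musculus) for metabolic stability, read by LC-MS, tested at 1 uM; on this read-out higher numbers stand for fast clearance and lower numbers for slow clearance. Compound 2 gives the higher of the two numbers, but its distance from compound 1 is small: a 1.5-fold higher number from compound 1 to compound 2 (0.19 log units; within the scatter). The two compounds therefore cannot be told apart on this read-out, and neither can be called the more stable one.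

Compound 3 `CCOC(=O)C1=C(C)N/C(=C/c2cc(C)n(-c3ccncc3)c2C)C1=O` has not been measured. It differs from compound 2 in one place: pyridin-4-yl in place of 3-methoxyphenyl on an aromatic nitrogen. For the measured compounds named here, the only step measured so far, the exchange of trifluoromethyl for methoxy from compound 1 to compound 2, stayed within the scatter, and it concerns a different change on the same six-membered ring rather than the swap of the whole ring for pyridin-4-yl. Going by the values given here, there is no measured step that bears directly on this change. Without a guide in the data, no shift beyond the scatter is expected in this assay, and the estimated step is a 1.4-fold lower number from compound 2 to compound 3 (0.13 log units; within the scatter). Compound 3 is expected to give about 110 mL.min-1.g-1, with a likely range from 50 mL.min-1.g-1 to 230 mL.min-1.g-1.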

Compound 3, intrinsic clearance in microsomes: 61 mL.min-1.g-1
Beside the measured number, compound 3's estimate is 1.8-fold (0.26 log units) above it; low and high end bracket the measured number.
By their numbers in this assay, from the lowest: compounds 3, 1 and 2 (each within the scatter of the next, the first and the last beyond it).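

Replacing the whole six-membered ring on the aromatic nitrogen can shift the number in this assay: the change from 3-methoxyphenyl to pyridin-4-yl gives a 2.5-fold lower number from compound 2 to compound 3 (0.39 log units; beyond the scatter), a modest step and the first one here to pass beyond the usual scatter. Measured against 3-(trifluoromethyl)phenyl at the same place, pyridin-4-yl gives a 1.6-fold lower number from compound 1 to compound 3 (0.20 log units; within the scatter), which stays within the scatter, so the size of this ring exchange depends on which substituted phenyl ring it replaces, and only the comparison with the methoxy compound separates the two clearly. No supporting measurement is available that accounts for either step.

These three compounds cannot show whether the ring nitrogen must sit where it does in pyridin-4-yl, and pyridin-3-yl or pyridin-2-yl at the same place would test that directly. On these data alone, it also remains open how a saturated ring such as piperidin-4-yl, or a phenyl ring carrying an amine or a carboxylic acid, would read in this clearance measurement, and whether the step seen here would carry over to a different group in place of the ethyl ester of the shared core.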